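The source may hold more compounds than are shown below. What is called first, only, known or untested is meant among the compounds shown, and "the series" means these compounds.

Of the compounds shown here, three from this series have been tested in a functional assay on HT-29 cells (Homo sapiens) for cytotoxicity, read by sulforhodamine B assay, with a stated time of 48 h; a higher number here means a weaker inhibitor, a lower number a stronger inhibitor. Compound 1 `CCc1ccccc1OS(=O)(=O)c1ccc(NC(=O)NCCCCl)cc1` gives 15000 nM in this assay. Compound 2 `Cc1ccccc1NS(=O)(=O)c1cccc(NC(=O)NCCCCl)c1` gives 42000 nM, and compound 3 `CCc1ccccc1NS(=O)(=O)c1cccc(NC(=O)NCCCCl)c1` gives 96000 nM. Compound 3 thus has the highest number of the three, which in this assay means the weakest inhibitor; its nearest neighbour is compound 2, and the step of a 2.3-fold higher number from compound 2 to compound 3 (0.36 log units; beyond the scatter) is modest but beyond the scatter, while compound 1 lies furthest below it.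

The next compound, compound 4 `CCCc1ccccc1NS(=O)(=O)c1cccc(NC(=O)NCCCCl)c1`, differs from compound 3 only by methyl in place of hydrogen on a saturated chain carbon, two bonds along the chain from an aromatic carbon. Among the compounds with values here, the one measured step that resembles this change is the lengthening of the same chain by one carbon, a 2.3-fold higher number from compound 2 to compound 3 (0.36 log units; beyond the scatter), which raised the number modestly. Extending the chain once more is therefore expected to move the number in the same direction, by a small amount, or possibly not beyond the scatter at all; no measured compound shows the longer chain, so the size of that move is uncertain.

On this basis the value for compound 4 is estimated at 130000 nM, with a range from 50000 nM to 320000 nM. The expected step is a 1.4-fold higher number from compound 3 to compound 4 (0.13 log units; within the scatter).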

Compound 4, half-maximal inhibitory concentration: 15000 nM
The estimate for compound 4 lay 8.7-fold (0.94 log units) above the measured number; the whole stated range lies above it.
By their numbers in this assay, from the lowest: compounds 1 and 4 (each within the scatter of the next); then compound 2; then compound 3.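

In this assay, lengthening the chain from ethyl to propyl reverses the direction seen one carbon earlier: a 2.3-fold higher number from compound 2 to compound 3 (0.36 log units; beyond the scatter) was a rise, whereas a 6.4-fold lower number from compound 3 to compound 4 (0.81 log units; beyond the scatter) is a fall, towards a stronger inhibitor. The propyl compound also ends up below the methyl compound, with a 2.8-fold lower number from compound 2 to compound 4 (0.45 log units; beyond the scatter) as the net change, so the effect of adding carbons at this position is not a steady push in one direction. Compound 3 goes against any simple rule that a longer chain gives a lower number, and compound 2 and compound 3 alone gave no hint of the fall, so each added methyl here has to be judged by measurement rather than by extending the previous step. Nothing available explains why the direction changes.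

On these data alone, it remains open whether a still longer chain such as butyl would bring the number lower again or raise it, which would show whether the fall at propyl continues. A branched group of similar size such as isopropyl would test whether the length of the chain or simply the number of its carbons matters at this position.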